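Carbamate-to-amine change in a growth-inhibition series

The source may hold more compounds than are shown below. What is called first, only, known or untested is meant among the compounds shown, and "the series" means these compounds.

Measured so far:
compound 1 `CC(C)[C@H](NC(=O)c1cc(Cl)ccc1OCCCNC(=O)OC(C)(C)C)C(=O)Nc1ccc([N+](=O)[O-])cc1Cl`: in a functional assay on MCF7 cells (Homo sapiens) for inhibition, read by MTT assay, with a stated time of 72 h (a higher number here means a weaker inhibitor, a lower number a stronger inhibitor), compound 1 gives > 10000 nM, which is a limit of the assay and not a number.
compound 2 `CC(C)[C@H](NC(=O)c1cc(Cl)ccc1OCCCN)C(=O)Nc1ccc([N+](=O)[O-])cc1Cl`: in this assay compound 2 gives > 10000 nM, again only a limit.
compound 3 `C[C@H](NC(=O)c1cc(Cl)ccc1OCCNC(=O)OC(C)(C)C)C(=O)Nc1ccc([N+](=O)[O-])cc1Cl`: in this assay compound 3 gives > 10000 nM, also a limit.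

Compounds 1 and 2 are joined by a single change, (hydrogen in place of tert-butoxycarbonyl on an amine nitrogen). Among the measured compounds shown here, since both of their values are limits, the step that the two limits leave unreadable from compound 1 to compound 2 cannot be read in either direction; what the pair shows is only that neither member reaches a measurable number within the range of the assay.

Compound 3 carries a different core from compound 1; the difference between the two cores is not broken down here. Compound 4 `C[C@H](NC(=O)c1cc(Cl)ccc1OCCN)C(=O)Nc1ccc([N+](=O)[O-])cc1Cl` has not yet been measured in this assay. It differs from compound 3 by hydrogen in place of tert-butoxycarbonyl on an amine nitrogen, and this is the same change as that from compound 1 to compound 2, with the same neighbour at the place of change in both pairs.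

For the measured compounds named here, all three values so far sit at the limit of > 10000 nM in this assay, at which 3 of the 3 values shown sit. Given that compound 3 itself sits at the limit, and that the same change made on compound 1 left compound 2 at the limit as well, compound 4 is expected to stay at or near the limit, with an estimated step that the limit leaves unreadable from compound 3 to compound 4. For compound 4 the estimate in this assay is 15000 nM, expected to lie between 5000 nM and 50000 nM, most likely reported again as a limit only.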

Compound 4, half-maximal inhibitory concentration: > 10000 nM
Compound 4 was reported as a limit; the forecaster's own chance of this, stated with the estimate: 85%; the middle value lies beyond the limit too.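

In this assay, compound 3 and compound 4 both give only limits and not numbers, so the step from tert-butoxycarbonyl to hydrogen on the amine nitrogen cannot be read in either direction: the limit of > 10000 nM in this assay, at which 4 of the 4 values shown sit.

The compounds shown leave open how the four would rank, and whether that change or the difference between the cores of compound 1 and compound 3 alters inhibition in this assay at all.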